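The source may hold more compounds than are shown below. What is called first, only, known or untested is meant among the compounds shown, and "the series" means these compounds.

Working notes on the shared core of compound 1 `CCC(O)CO[C@H](CC=C(C)C)C1=CC(=O)c2c(O)ccc(O)c2C1=O`, carried through compound 2 `CCCCCCC(C)(O)CC(=O)O[C@H](CC=C(C)C)C1=CC(=O)c2c(O)ccc(O)c2C1=O` and, still to be measured, compound 3 `CCC(O)(CC)CC(=O)O[C@H](CC=C(C)C)C1=CC(=O)c2c(O)ccc(O)c2C1=O`.

In a functional assay on HeLa cells (Homo sapiens) for cytotoxicity, read by MTT assay (on this read-out lower numbers stand for stronger inhibition and higher numbers for weaker inhibition), compound 1 gives 28700 nM. For compound 2 only a limit of this assay is reported, > 100000 nM, so that compound 2 stands at the limit of > 100000 nM in this assay, at which 1 of the 2 values shown sits, and no number for it is known. Between compound 1 and compound 2 the two values therefore show only that compound 2 sits at the limit while compound 1 sits at a number.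

The step from compound 2 to compound 3 is 1-ethyl-1-hydroxypropyl in place of 1-hydroxy-1-methylheptyl on a saturated chain carbon bound to a carbonyl carbon. Among the compounds with values here, no measured step of this kind is available. The expectation is a step of a number no higher from compound 2 to compound 3 (the limit leaves the size open), no larger than the usual scatter in either direction. Compound 3 is accordingly estimated at 100000 nM, with a range from 30000 nM to 300000 nM, and a fair chance that this assay again reports only a limit.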

Compound 3, half-maximal inhibitory concentration: 52000 nM
Beside the measured number, compound 3's estimate is 1.9-fold (0.28 log units) above it; measured number inside the range.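

In this assay, 1-ethyl-1-hydroxypropyl in place of 1-hydroxy-1-methylheptyl on a saturated chain carbon bound to a carbonyl carbon gives an at least 1.9-fold lower number from compound 2 to compound 3 (0.28 log units; that floor lies within the scatter). Compound 2 remains a limit and not a number: the limit of > 100000 nM in this assay, at which 1 of the 3 values shown sits. Within the data shown here, compound 3 supplies the first number for an acyl group on this oxygen, and (2-ethyl-2-hydroxybutyl)carbonyl in place of 2-hydroxybutyl on an oxygen on a saturated carbon gives a 1.8-fold higher number from compound 1 to compound 3 (0.26 log units; within the scatter), so this read-out does not separate compound 1 from compound 3.

The compounds shown leave open how large the step between the two chains really is, with only its floor known. They also leave open what an amine or a carboxylic acid in place of the hydroxy group of 1-ethyl-1-hydroxypropyl would give.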